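The compounds below may be only part of what the source reports. "The series", "measured", "known", "first", "only" and "open" are said of these compounds alone.

Compound 1 `CCn1c(Nc2ccccc2C)nc2ccsc2c1=O`: 88 nM
Compound 2 `CCn1c(Nc2cccc(C)c2)nc2ccsc2c1=O`: > 1000 nM, a limit of the assay
Compound 3 `CCn1c(Nc2ccc(C)cc2)nc2ccsc2c1=O`: > 1000 nM, a limit of the assay

All three compounds share one core and carry a single methyl on the attached benzene ring; only the place of that methyl changes. For the measured compounds named here, in an assay on isolated protein for inhibition of high affinity 3',5'-cyclic-AMP phosphodiesterase 7A (Homo sapiens) (on this read-out higher numbers stand for weaker inhibition and lower numbers for stronger inhibition), compound 1 gives 88 nM, and this is the only real number among the three. Compound 2 reaches only a limit of the assay, > 1000 nM. Compound 3 likewise reaches only a limit, > 1000 nM. Compound 1 therefore stands apart from the limit of > 1000 nM in this assay, at which 2 of the 3 values shown sit, which is all that the other two show.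

Compound 4 `CCn1c(Nc2ccccc2F)nc2ccsc2c1=O` is built from compound 1 by one exchange, (fluoro in place of methyl on an aromatic carbon). Going by the values given here, no pair of measured compounds shows this kind of exchange, so the size of the step cannot be read from anything measured; the data only show that a methyl where compound 1 carries it gives a number, while the other methyl placements give limits. A fluoro at that same place is expected to keep the compound measurable but somewhat weaker than compound 1, with the step of a 2.3-fold higher number from compound 1 to compound 4 (0.36 log units; beyond the scatter) expected to be modest, near the edge of the usual scatter. Compound 4 is thus estimated at 200 nM in this assay, with a likely range from 60 nM to 900 nM.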

Compound 4, half-maximal inhibitory concentration in the high affinity 3',5'-cyclic-AMP phosphodiesterase 7A assay: 61 nM
Estimate against measurement, compound 4: 3.3-fold (0.52 log units) above, and the stated range covers the measured number.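

In the high affinity 3',5'-cyclic-AMP phosphodiesterase 7A assay, the exchange of methyl for fluoro on the aromatic carbon ortho to a large group gives a 1.4-fold lower number from compound 1 to compound 4 (0.16 log units; within the scatter), so this place on the ring is not tied to a methyl: a second, different group also gives a real number here. Compound 2 and compound 3, which carry the methyl elsewhere on the ring, each stay at a limit of the assay, so until now a measured number rested on compound 1 alone. The exchange also brings something the first three compounds could not show, because it keeps the reading in the high affinity 3',5'-cyclic-AMP phosphodiesterase 7A assay within the scatter while the number for solubility in a physicochemical assay for solubility, in phosphate buffer, at pH 6.8 (a lower number here means a less soluble compound, a higher number a more soluble compound), goes up: the measured solubility of compound 1, 10.1 ug/mL, and of compound 4, 26.1 ug/mL, a 2.6-fold higher number (0.41 log units; beyond the scatter) In the physicochemical assay compound 1 gives 10.1 ug/mL, and compound 4 gives 26.1 ug/mL.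

The compounds shown leave open whether a chloro, a methoxy or a longer chain such as ethyl would also give a real number at this same place. They also leave open whether a fluoro at the other two places on the ring would end at a limit, as the methyl does there, and whether a solubility gain like this one would hold with an amine on the ring.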